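A few compounds are considered here, and "the series" means these few. Any claim that something is new, unique, unknown or untested is made for them only; others in the source may bear on it.

Working notes on the series in a functional assay on HCT-116 cells (Homo sapiens) for cytotoxicity, read by MTT assay, with a stated time of 72 h; a lower number here means a stronger inhibitor, a higher number a weaker inhibitor.

Three compounds carry numbers. Compound 1 `O=C1c2c[n+]([O-])c3ccccc3c2C(=O)c2c1c1ccccc1n2CCCCN1CCCCC1` gives 200 nM. Compound 2 `CCCN1CCN(CCCCn2c3c(c4ccccc42)C(=O)c2c[n+]([O-])c4ccccc4c2C3=O)CC1` gives 790 nM. Compound 3 `CCCCN1CCN(CCCCn2c3c(c4ccccc42)C(=O)c2c[n+]([O-])c4ccccc4c2C3=O)CC1` gives 1920 nM, the highest of the three: a 9.6-fold higher number from compound 1 to compound 3 (0.98 log units; beyond the scatter), and a 2.4-fold higher number from compound 2 to compound 3 (0.39 log units; beyond the scatter). Within this set compound 3 is the weakest inhibitor. The other measured step, a 4.0-fold higher number from compound 1 to compound 2 (0.60 log units; beyond the scatter), is a change of the ring rather than of the chain on it.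

Compound 4 `CN1CCN(CCCCn2c3c(c4ccccc42)C(=O)c2c[n+]([O-])c4ccccc4c2C3=O)CC1` has not yet been measured. It differs from compound 3 by hydrogen in place of propyl on a saturated chain carbon bound to an amine nitrogen in a ring.

The step that bears most directly on this change is a 2.4-fold higher number from compound 2 to compound 3 (0.39 log units; beyond the scatter), where the chain on the ring nitrogen is lengthened by one carbon. Going by the values given here, compound 4 shortens that chain by three carbons, so the expectation is a lower number than compound 3 in this assay, most plausibly passing below compound 2 as well; no measured compound, however, shows the methyl case, and the bearing of compound 1 is indirect. The expected step is a 4.8-fold lower number from compound 3 to compound 4 (0.68 log units; beyond the scatter). For compound 4 the estimate in this assay is 400 nM, with a range from 150 nM to 1000 nM.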

Compound 4, half-maximal inhibitory concentration: 10 nM
The estimate for compound 4 lay 40-fold (1.60 log units) above the measured number; measured number outside the range, below it.
By their numbers in this assay, from the lowest: compound 4; then compound 1; then compound 2; then compound 3.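

In this assay, the group carried on the saturated chain carbon bound to an amine nitrogen in a ring matters far more than the earlier propyl-to-butyl comparison showed: going from 4-butylpiperazin-1-yl to 4-methylpiperazin-1-yl gives the large step (a 190-fold lower number from compound 3 to compound 4 (2.28 log units; beyond the scatter)), and the comparison with the propyl compound is nearly as large (a 79-fold lower number from compound 2 to compound 4 (1.90 log units; beyond the scatter)), both well beyond the modest earlier step (a 2.4-fold higher number from compound 2 to compound 3 (0.39 log units; beyond the scatter)). The three piperazines rise in the order methyl, propyl, butyl, with most of the change lying between methyl and propyl, and compound 4 also reverses the earlier standing of the piperazines against piperidin-1-yl (a 20-fold lower number from compound 1 to compound 4 (1.30 log units; beyond the scatter)), so the piperazine ring does not by itself give a higher number than piperidin-1-yl in this set. No measurement shown here accounts for the size of these steps.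

Open, on these data alone, is whether ethyl or hydrogen in place of methyl stays with compound 4 or moves towards compound 2, which would locate where between methyl and propyl the change falls. Also open, as far as these compounds go, is whether a shorter chain on the aromatic nitrogen keeps this ranking of the 4-methylpiperazin-1-yl and propyl cases.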